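A few compounds are considered here, and "the series" means these few. Any claim that something is new, unique, unknown or untested is made for them only; others in the source may bear on it.

Measured so far:
compound 1 `CCCNc1nc(Cl)nc(N[C@@H](C)c2ccccc2)n1`: 32400 nM
compound 2 `CCCN(CCC)c1nc(Cl)nc(N[C@@H](C)c2ccccc2)n1`: 331 nM

For the measured compounds named here, in an ADME assay on the whole organism for inhibition, with Oryza sativa as the target, with a stated time of 4 days (on this read-out higher numbers stand for weaker inhibition and lower numbers for stronger inhibition), compound 2 stands with the lower of the two numbers, and the only step seen is a 98-fold lower number from compound 1 to compound 2 (1.99 log units; beyond the scatter). Compound 3 `CCN(CC)c1nc(Cl)nc(N[C@@H](C)c2ccccc2)n1` differs from compound 2 by diethylamino in place of dipropylamino on an aromatic carbon. That single step bears on this change only loosely: it shows that what sits on the ring nitrogen matters greatly, while the change to compound 3 is a smaller one. A modest step toward weaker inhibition is therefore expected, a 2.1-fold higher number from compound 2 to compound 3 (0.33 log units; beyond the scatter). For compound 3 the estimate in this assay is 700 nM, within 250 nM to 2000 nM.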

Compound 3, half-maximal inhibitory concentration: 380 nM
For compound 3 the middle estimate is 1.8-fold (0.27 log units) above the measured one; measured number inside the range.
By their numbers in this assay, from the lowest: compounds 2 and 3 (each within the scatter of the next); then compound 1.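

In this assay the shorter group does as well as the longer one: dipropylamino and diethylamino on this aromatic carbon cannot be told apart, with a 1.1-fold higher number from compound 2 to compound 3 (0.06 log units; within the scatter). The large step seen earlier is also not tied to propyl chains, since diethylamino in place of propylamino gives an 85-fold lower number from compound 1 to compound 3 (1.93 log units; beyond the scatter). Nothing at hand speaks to what lies behind either step. The compounds shown leave open whether dimethylamino, dibutylamino or a cyclic amine such as piperidine on this carbon would stay at the level of compound 2 and compound 3.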